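The source may report more compounds than this note shows. Statements on the series, on what has been measured and on what is new or still open speak of the compounds shown alone.

For the measured compounds named here, in a functional assay on HeLa cells (Homo sapiens) for antiproliferative activity, read by sulforhodamine B assay, with a stated time of 48 h (a higher number here means a weaker inhibitor, a lower number a stronger inhibitor), compound 1 (`COc1ccc2nc(-c3ccc(N/C=C\C(=O)c4ccc(OC)c(O)c4)c(C)c3)sc2c1`) gives 12000 nM and compound 2 (`COc1ccc2nc(-c3ccc(N/C=C\C(=O)c4ccc(OC)c(O)c4)cc3)sc2c1`) gives 6900 nM, so the only two measured compounds stand within the scatter of each other. Going by the values given here, the single measured step, a 1.7-fold lower number from compound 1 to compound 2 (0.24 log units; within the scatter), is hydrogen in place of methyl on an aromatic carbon. Compound 3 (`COc1ccc2nc(-c3ccc(N/C=C\C(=O)c4ccc(OC)c(F)c4)c(C)c3)sc2c1`) keeps the core of compound 1 but alters a different group: fluoro in place of hydroxy on an aromatic carbon. In words, this is fluoro in place of hydroxy on an aromatic carbon, turning 3-hydroxy-4-methoxyphenyl into 3-fluoro-4-methoxyphenyl. Among the compounds with values here, both measured compounds carry the hydroxy group, so the data hold no direct measure of this exchange, and the one measured step bears on it only weakly. It shows how close the two values lie, not what the new group will do. With no evidence for a direction, no shift beyond the scatter is expected, though the uncertainty is wide. The expected change is a 1.2-fold lower number from compound 1 to compound 3 (0.08 log units; within the scatter), which is an estimate anchored on the value of compound 1, 12000 nM. Compound 3 is estimated at 10000 nM, with an expected range from 3500 nM to 30000 nM.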

Compound 3, half-maximal inhibitory concentration: 600 nM
Compound 3: middle estimate off by 17-fold (1.22 log units), on the high side; measured number below the stated range.
By their numbers in this assay, from the lowest: compound 3; then compounds 2 and 1 (each within the scatter of the next).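

In this assay, fluoro in place of hydroxy on an aromatic carbon, ortho to a methoxy group, gives a 20-fold lower number from compound 1 to compound 3 (1.30 log units; beyond the scatter), a large step beyond the scatter. This shows that the activity depends strongly on the group at this position, which the earlier step could not show: a 1.7-fold lower number from compound 1 to compound 2 (0.24 log units; within the scatter) concerned a methyl group elsewhere in the molecule and stayed within the scatter. By the counts for the two groups, hydroxy brings one hydrogen-bond donor and one hydrogen-bond acceptor and fluoro brings neither, but no measurement shown explains why this exchange has so large an effect.

The compounds shown leave open whether the same exchange would give a step of similar size on the core of compound 2, which carries hydrogen in place of the methyl group. They also leave open whether the outcome is particular to fluoro, since a chloro group or an amine at this position could stand close to compound 3, close to compound 1 or apart from both.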